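The source may report more compounds than this note shows. Statements on the series, on what has been measured and on what is new or still open speak of the compounds shown alone.

Compound 1 `CN1C(=O)C(C2=NS(=O)(=O)c3cc(NS(C)(=O)=O)ccc3N2)=C(O)C2CCCC21`: "not determined" (no result reported)
Compound 2 `CS(=O)(=O)Nc1ccc2c(c1)S(=O)(=O)N=C(C1=C(O)[C@H]3CCC[C@H]3N(Cc3ccc(F)c(F)c3)C1=O)N2`: > 1000 nM
Compound 3 `CS(=O)(=O)Nc1ccc2c(c1)S(=O)(=O)N=C(C1=C(O)[C@H]3CCC[C@H]3N(Cc3cccc(C(F)(F)F)c3)C1=O)N2`: > 33000 nM

The account follows the step from compound 1 to compound 4 `CS(=O)(=O)Nc1ccc2c(c1)S(=O)(=O)N=C(C1=C(O)C3CCCC3N(C3CCCCC3)C1=O)N2` in an ADME assay on Huh-7 cells (Homo sapiens) for cytotoxicity, with a stated time of 72 h; on this read-out higher numbers stand for lower toxicity in this test and lower numbers for higher toxicity in this test. Compound 1 has no number of its own in this assay; for compound 1 the entry reads "not determined" (no result reported). The two further values shown for the series are limits rather than numbers. For compound 2 this assay reports only a limit, > 1000 nM. For compound 3 the result is likewise a limit, > 33000 nM. The step that the two limits leave unreadable from compound 2 to compound 3 cannot be sized because both of its ends are limits, the limit of > 1000 nM in this assay, at which 1 of the 3 values shown sits, and (the limit of > 33000 nM in this assay, at which 1 of the 3 values shown sits).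

Compound 4 differs from compound 1 by cyclohexyl in place of methyl on an amide-type nitrogen in a ring. No measured step touches this change: the single step shown concerns a different position and is itself unreadable, so no size and no direction can be taken from it. Compound 1 has no number to start from, and the limits of compound 2 and compound 3 only say that the series is seen at the upper end of this assay. On that basis compound 4 is expected to give about 20000 nM, with a range from 3000 nM to 100000 nM.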

Compound 4, half-maximal cytotoxic concentration: > 10000 nM
Compound 4: no number, only a limit (the forecaster's own chance of this, stated with the estimate: 70%); the middle value lies beyond the limit too.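

In this assay compound 4 gives > 10000 nM, which is a limit and not a number. Compound 1 has no number to set against it, so no step can be read from compound 1 to compound 4. The compounds shown leave open what cyclohexyl in place of methyl does to the half-maximal cytotoxic concentration.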